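Side chain replacement from compound 1 to compound 4

The source may hold more compounds than are shown below. What is called first, only, known or untested is meant among the compounds shown, and "the series" means these compounds.

Compound 1 `COc1ccc(-c2oc3c(OC)c(OC)cc(OCCCC(=O)N4CCN(C)CC4)c3c(=O)c2O)cc1` reaches only a limit, > 40000 nM, in a functional assay on DU-145 cells (Homo sapiens) for antiproliferative activity, read by sulforhodamine B assay, with a stated time of 48 h; a lower number here means a stronger inhibitor, a higher number a weaker inhibitor. Compound 2 `COc1ccc(-c2oc3c(OC)c(OC)cc(OCCCCC(=O)NCc4ccccn4)c3c(=O)c2O)cc1` likewise gives only a limit there, > 40000 nM. Compound 3 `CCCCCN(C)C(=O)CCCCCOc1cc(OC)c(OC)c2oc(-c3ccc(OC)cc3)c(O)c(=O)c12` gives a number, 22500 nM. The step of an at least 1.7-fold lower number from compound 1 to compound 3 (0.24 log units; that floor lies within the scatter) and the step of an at least 1.7-fold lower number from compound 2 to compound 3 (0.24 log units; that floor lies within the scatter) are floors that lie within the scatter, and the step that the two limits leave unreadable from compound 1 to compound 2 cannot be read between the two limits; the limit of > 40000 nM in this assay, at which 2 of the 3 values shown sit, marks where two of the three values sit. Compound 4 `COc1ccc(-c2oc3c(OC)c(OC)cc(OC(C)CN(C)C)c3c(=O)c2O)cc1` differs from compound 1 by 1-((dimethylamino)methyl)ethyl in place of 3-((4-methylpiperazin-1-yl)carbonyl)propyl on an oxygen on an aromatic ring. Among the compounds with values here, none of the measured steps touches this kind of change, since all of them alter the chain end while keeping the chain itself. Compound 4 is therefore expected to stay close to its parent, as an at least 1.6-fold lower number from compound 1 to compound 4 (0.20 log units; that floor lies within the scatter), with an estimated 25000 nM spanning 8000 nM to 60000 nM.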

Compound 4, half-maximal inhibitory concentration: 4380 nM
Compound 4: the middle estimate sits 5.7-fold (0.76 log units) above what was measured, and the stated range ends above it.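

Replacing the whole chain on the oxygen on an aromatic ring, rather than only its end, gives a readable change in this assay: an at least 9.1-fold lower number from compound 1 to compound 4 (0.96 log units; beyond the scatter). Of the steps shown, this is the only one printed as beyond the scatter, and the entering 1-((dimethylamino)methyl)ethyl carries no ring and no carbonyl. The step is only a floor, and compound 1 stands at a limit: the limit of > 40000 nM in this assay, at which 2 of the 4 values shown sit.

As far as these compounds go, it remains open whether the change follows from the shorter chain, the loss of the amide carbonyl or the branching methyl. A straight 2-(dimethylamino)ethyl chain or a longer aminoalkyl chain would help separate these.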